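The source may report more compounds than this note shows. Statements on the series, on what has been measured and on what is new or still open speak of the compounds shown alone.

Among the compounds with values here, compound 1 `COc1ccc(/C=C(/F)c2cc(OC)c(OC)c(OC)c2)cc1O` gives 100 nM in a functional assay on HT-29 cells (Homo sapiens) for cytotoxicity, read by sulforhodamine B assay, with a stated time of 72 h (on this read-out higher numbers stand for weaker inhibition and lower numbers for stronger inhibition), the highest number among the two compounds measured so far. Compound 2 `COc1ccc(/C(F)=C(/F)c2cc(OC)c(OC)c(OC)c2)cc1N` gives 4.5 nM in this assay, and the gap between the two lies beyond the scatter. Compound 3 `COc1ccc(/C=C(/F)c2cc(OC)c(OC)c(OC)c2)cc1[N+](=O)[O-]` differs from compound 1 by nitro in place of hydroxy on an aromatic carbon. Within the data shown here, no measured pair shows this change, so the step is expected to be small, if anything toward a higher number, and may not exceed the scatter; the expected step is a 1.5-fold higher number from compound 1 to compound 3 (0.18 log units; within the scatter). Compound 3 is therefore estimated at 150 nM, within a range from 30 nM to 800 nM.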

Compound 3, half-maximal inhibitory concentration: 32 nM
The estimate for compound 3 lay 4.7-fold (0.67 log units) above the measured number, and the stated range covers the measured number.
By their numbers in this assay, from the lowest: compound 2; then compound 3; then compound 1.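

In this assay, nitro in place of hydroxy on this aromatic carbon, ortho to a methoxy group, brings a 3.1-fold lower number from compound 1 to compound 3 (0.49 log units; beyond the scatter). The hydroxy group, with its hydrogen-bond donor, is therefore not required at this place for a low number on this read-out. Nothing available explains the step. From the compounds shown here alone, whether a nitrile or a carboxylic acid at this place would sit nearer compound 3 or compound 1 stays open. Going by these compounds, compound 2 differs from both in more than one place, so what an amine would do on the core of compound 1 also stays open.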